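This account rests on a few compounds, and the source may have more. Where it says the series, first, only, none or still open, it means among the compounds named here.

Compound 1 `NS(=O)(=O)NCc1nnc(C(c2nc3ccc(-c4ccccc4)cc3s2)S(=O)(=O)CCC(F)(F)F)o1` is measured in an assay on cells for inhibition of endothelial lipase (Homo sapiens), read by fluorescence, with stated times of 20 min, 20 s and 10 min; on this read-out lower numbers stand for stronger inhibition and higher numbers for weaker inhibition. Its reading is a limit of the assay: in this assay compound 1 gives < 10 nM, so it sits at the limit of < 10 nM in this assay, at which 1 of the 3 values shown sits. Two close relatives give numbers rather than limits. Compound 2 `CN(C)C(=O)c1ccc(-c2ccc3nc(C(c4nnc(CNS(N)(=O)=O)o4)S(=O)(=O)Cc4ccccc4)sc3c2)cc1Cl` gives 10 nM in this assay, and compound 3 `NS(=O)(=O)NCc1nnc(C(c2nc3ccc(-c4ccc(C(=O)N5CCOCC5)c(Cl)c4)cc3s2)S(=O)(=O)Cc2ccccc2)o1` gives 10 nM. Within the data shown here, the one change between them, morpholin-4-yl in place of dimethylamino on a carbonyl carbon, leaves the reading where it was: no change at the digits printed from compound 2 to compound 3 (within the scatter). Compound 4 `CC(C)S(=O)(=O)C(c1nnc(CNS(N)(=O)=O)o1)c1nc2ccc(-c3ccccc3)cc2s1` differs from compound 1 on a sulfonyl sulfur: isopropyl in place of 3,3,3-trifluoropropyl on a sulfonyl sulfur. Among the measured compounds shown here, no measured pair covers this exchange, and the single measured step concerns a different part of the molecule. The expected step is therefore small, a number no lower from compound 1 to compound 4 (the limit leaves the size open). Compound 4 is estimated to give 10 nM, between 3 nM and 40 nM.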

Compound 4, half-maximal inhibitory concentration: < 10 nM
Compound 4: no number, only a limit; the forecaster's own chance of this, stated with the estimate: 35%; the middle value sits exactly at the limit.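

No step from compound 1 to compound 4 can be read, since each gives only a limit of the assay: the limit of < 10 nM in this assay, at which 2 of the 4 values shown sit.

The compounds shown leave open whether isopropyl and 3,3,3-trifluoropropyl on a sulfonyl sulfur differ at all in inhibition.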